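The compounds below may be only part of what the source reports. "The series", "measured", "known", "first", "only" and "open" are said of these compounds alone.

Compound 1 `CC1=NC(C)=C(C(=O)O)C(c2cccc(C(=O)O)c2)/C1=C(\O)OC/C=C/c1ccccc1`, compound 2 `CC1=NC(C)=C(C(=O)O)C(c2cccc(C)c2)/C1=C(\O)OC/C=C/c1ccccc1`, compound 3 `CC1=NC(C)=C(C(=O)O)C(c2cccc(Br)c2)/C1=C(\O)OC/C=C/c1ccccc1`.

In a functional assay on thoracic aorta for inhibition of Voltage-gated L-type calcium channel (Rattus norvegicus) (a higher number here means a weaker inhibitor, a lower number a stronger inhibitor), compound 1 gives only a limit, > 10000 nM, a value that is a limit of the assay (the limit of > 10000 nM in this assay, at which 1 of the 3 values shown sits). Compound 2 gives 76 nM. Compound 3 gives 10 nM, the lowest number among the measured compounds; the step of a 7.6-fold lower number from compound 2 to compound 3 (0.88 log units; beyond the scatter) was modest, while the step of an at least 1000-fold lower number from compound 1 to compound 3 (3.00 log units; beyond the scatter) was large. Compound 4 `CC1=NC(C)=C(C(=O)O)C(c2cccc(I)c2)/C1=C(\O)OC/C=C/c1ccccc1` carries iodo in place of bromo on an aromatic carbon. Among the compounds with values here, the one measured step that touches this position with a halogen, a 7.6-fold lower number from compound 2 to compound 3 (0.88 log units; beyond the scatter), went to a lower number, so a further small move in that direction, or none beyond the scatter, is expected. The estimated step of a 1.4-fold lower number from compound 3 to compound 4 (0.15 log units; within the scatter) is small. For compound 4 the estimate is 7 nM, between 2.5 nM and 25 nM.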

Compound 4, half-maximal inhibitory concentration: 13 nM
For compound 4 the middle estimate is 1.9-fold (0.27 log units) below the measured one; the range from low to high includes it.
By their numbers in this assay, from the lowest: compounds 3 and 4 (each within the scatter of the next); then compound 2. At a limit, above all of these: compound 1.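

In this assay, iodo in place of bromo on the aromatic carbon meta to a large group gives a 1.3-fold higher number from compound 3 to compound 4 (0.11 log units; within the scatter), so the drop seen from methyl to bromo does not continue from bromo to iodo. Iodo, like bromo, stands clear of methyl, with a 5.8-fold lower number from compound 2 to compound 4 (0.77 log units; beyond the scatter). Against carboxy, where compound 1 gives only a limit, the step is an at least 760-fold lower number from compound 1 to compound 4 (2.88 log units; beyond the scatter).

From the compounds shown here alone, whether chloro, fluoro or an amine at this position would match bromo and iodo remains open. So does whether a methoxy group would behave like methyl or like the halogens.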